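Amino for Chloro on a Purine Core: an Expectation

A few compounds are considered here, and "the series" means these few. Any claim that something is new, unique, unknown or untested is made for them only; others in the source may bear on it.

Three measured compounds share a core bearing a chloromethyl-substituted benzyl group. In a functional assay on EKVX cells (Homo sapiens) for cytotoxicity, read by sulforhodamine B assay, with a stated time of 48 h (a lower number here means a stronger inhibitor of growth, a higher number a weaker inhibitor of growth), compound 1 `ClCc1ccccc1Cn1cnc2c(Cl)nc(Cl)nc21` gives 1770 nM, the second highest of the three numbers. Compound 3 `ClCc1cccc(Cn2cnc3nc(Cl)nc(Cl)c32)c1` gives 930 nM, which lies within the scatter of compound 1, while compound 2 `ClCc1cccc(Cn2cnc3c(Cl)ncnc32)c1` gives 18600 nM, a gap beyond the scatter. Compound 2 and compound 3 differ both in the benzyl substitution and in the count of chloro groups on the core, so their gap is not assigned to one change. Compound 4 `Nc1nc(Cl)c2ncn(Cc3ccccc3CCl)c2n1` differs from compound 1 by amino in place of chloro on an aromatic carbon between two ring nitrogen atoms. For the measured compounds named here, no measured pair isolates this change, so the expected step of a 4.0-fold higher number from compound 1 to compound 4 (0.60 log units; beyond the scatter) rests on the weaker number of compound 2. Compound 4 is estimated at 7000 nM, within 2500 nM to 20000 nM.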

Compound 4, concentration for 50% growth inhibition: 15900 nM
For compound 4 the middle estimate is 2.3-fold (0.36 log units) below the measured one; measured number inside the range.
By their numbers in this assay, from the lowest: compounds 3 and 1 (each within the scatter of the next); then compounds 4 and 2 (each within the scatter of the next).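

In this assay the series now holds its first pair differing in one place, and it shows a 9.0-fold higher number from compound 1 to compound 4 (0.95 log units; beyond the scatter) for amino in place of chloro on an aromatic carbon between two ring nitrogen atoms. For the compounds shown here, in this one pair, the chloro group at this position goes with the lower number, which the earlier compounds could not show. Nothing measured here explains the step.

From the compounds shown here alone, whether a methoxy or methylamino group at this position would stay closer to compound 1 or to compound 4 remains open. So does whether the same change on compound 3 would give a similar step.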